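Trifluoromethyl for Chloro on the Pendant Phenyl Ring

The source may report more compounds than this note shows. Statements on the series, on what has been measured and on what is new or still open speak of the compounds shown alone.

Measured so far:
Compound 1 `O=C1C=CC2(C=C1)OCC(=O)N2c1nc(-c2ccc3ccccc3c2Br)nn1-c1ccccc1` gives 50 nM in a functional assay on MDA-MB-231 cells (Homo sapiens) for antiproliferative activity, with a stated time of 5 days; on this read-out higher numbers stand for weaker inhibition and lower numbers for stronger inhibition.
Compound 2 `O=C1C=CC2(C=C1)OCC(=O)N2c1nc(-c2ccc3ccccc3c2)nn1-c1ccc(Cl)cc1` gives 70 nM in this assay .

Of the compounds shown here, two have numbers in this assay so far. Compound 2 and compound 1 stand within the usual scatter of each other, so the measurements do not tell them apart, and neither can be called the stronger inhibitor. The two structures also differ in more than one place, so no single structural step can be read from their pair.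

Compound 3 `O=C1C=CC2(C=C1)OCC(=O)N2c1nc(-c2ccc3ccccc3c2)nn1-c1ccc(C(F)(F)F)cc1` has not yet been measured in this assay . It differs from compound 2 in one place only: trifluoromethyl in place of chloro on an aromatic carbon. Within the data shown here, no measured pair shows what this exchange does on this core, so the expectation rests on the value of compound 2 alone. The step from compound 2 to compound 3 is expected to be no change at the digits printed from compound 2 to compound 3 (within the scatter), that is, nothing beyond the scatter in either direction. Compound 3 is therefore estimated to give about 70 nM in this assay , with a range from 30 nM to 170 nM.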

Compound 3, half-maximal inhibitory concentration: 70 nM
Beside the measured number, compound 3's estimate shows no gap at the digits printed, within the range that was stated.
By their numbers in this assay, from the lowest: compounds 1, 2 and 3 (each within the scatter of the next).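

In this assay, among these compounds, the change from 4-chlorophenyl to 4-(trifluoromethyl)phenyl gives no change at the digits printed from compound 2 to compound 3 (within the scatter), and this is the first pair that differs in one place only, so a single structural step can finally be read. At this position on the shared core, a group of 4 heavy atoms can therefore replace a single chlorine atom without a change that the measurements can detect, which means that this exchange leaves the antiproliferative read-out where it was. No measurement available here bears on why the two compounds match, so the result stands as an observation without an explanation.

The compounds shown leave open whether this position would accept groups of a different kind, such as an amine, a carboxylic acid or a longer chain like butyl, as readily as it accepts chloro and trifluoromethyl. They also leave open whether the same exchange would read the same way on another ring of the core, since only this one position has been compared.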